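Trifluoromethoxy to methoxy in a growth-inhibition series

The source may hold more compounds than are shown below. What is called first, only, known or untested is meant among the compounds shown, and "the series" means these compounds.

In a functional assay on Gurav cells (Homo sapiens) for inhibition, read by sulforhodamine B assay (a lower number here means a stronger inhibitor of growth, a higher number a weaker inhibitor of growth), compound 1 `Oc1cccc2[nH]c(-c3ccc(-c4ccc(-c5ccc(C(F)(F)F)cc5)cc4)cc3)nc12` gives 3190 nM and compound 2 `Oc1cccc2[nH]c(-c3ccc(-c4ccc(-c5ccc(OC(F)(F)F)cc5)cc4)cc3)nc12` gives 3600 nM alongside it. Compound 2 therefore stands level with compound 1, with nothing to separate them. Compound 3 `COc1ccc(-c2ccc(-c3ccc(-c4nc5c(O)cccc5[nH]4)cc3)cc2)cc1` has not yet been measured. It differs from compound 2 by methyl in place of trifluoromethyl on an oxygen on an aromatic ring and so carries 4-methoxyphenyl where compound 2 carries 4-(trifluoromethoxy)phenyl. Among the measured compounds shown here, only one measured step bears on this change, namely a 1.1-fold higher number from compound 1 to compound 2 (0.05 log units; within the scatter) for trifluoromethoxy in place of trifluoromethyl. For the measured compounds named here, no measured compound carries methoxy, so that step is only a weak guide. The estimate is a 1.1-fold lower number from compound 2 to compound 3 (0.02 log units; within the scatter) and no shift beyond the scatter is expected in this assay with neither direction favoured. For compound 3 the expected value is 3400 nM with an estimated range from 1500 nM to 8000 nM for this measurement.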

Compound 3, concentration for 50% growth inhibition: 6630 nM
Beside the measured number, compound 3's estimate is 2.0-fold (0.29 log units) below it, within the range that was stated.
By their numbers in this assay, from the lowest: compounds 1, 2 and 3 (each within the scatter of the next, the first and the last beyond it).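

In this assay, methyl in place of trifluoromethyl on an oxygen on an aromatic ring gives a 1.8-fold higher number from compound 2 to compound 3 (0.27 log units; within the scatter), so this change does not clearly separate compound 3 from compound 2. Measured against the trifluoromethyl group of compound 1, however, the methoxy group gives a 2.1-fold higher number from compound 1 to compound 3 (0.32 log units; beyond the scatter), a modest gap that makes compound 3 a weaker inhibitor of growth than compound 1, whereas the trifluoromethoxy group of compound 2 could not be told apart from compound 1. Nothing available here accounts for this result.

Going by these compounds, it remains open whether an ethoxy group, a free hydroxyl or an amine in this place would stay level with compound 2 or fall further from compound 1. All three compounds share one core, so whether this modest gap would hold on a different core is also unanswered.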